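Compound 3: 2-(Dimethylamino)pyridin-4-yl Replaces 3-Cyano-4-fluorophenyl

The source may report more compounds than this note shows. Statements on the series, on what has been measured and on what is new or still open speak of the compounds shown alone.

Compound 2 `N#Cc1cc(-c2nc(C(c3ccc(F)cc3)c3ccc(F)cc3)sc2CC(=O)O)ccc1F` carries a 3-cyano-4-fluorophenyl group on the shared core. In an in vitro functional assay on HEK285-7 cells for antagonist activity at prostaglandin D2 receptor 2 (Homo sapiens), read by BRET and beta-arrestin recruitment (a lower number here means a smaller maximal response, a higher number a larger maximal response), compound 2 gives 80%, the highest of the two values known here. Among the measured compounds shown here, its nearest neighbour is compound 1 `N#Cc1ccc(-c2nc(C(c3ccc(F)cc3)c3ccc(F)cc3)sc2CC(=O)O)cc1`, which in this assay gives 30%; the step of a number 50 percentage points higher from compound 1 to compound 2 (beyond the scatter) is the only measured step. Compound 3 `CN(C)c1cc(-c2nc(C(c3ccc(F)cc3)c3ccc(F)cc3)sc2CC(=O)O)ccn1` changes the same position once more: 2-(dimethylamino)pyridin-4-yl in place of 3-cyano-4-fluorophenyl on an aromatic carbon. For the measured compounds named here, the measured step touches exactly this position and was large, so the group placed there clearly matters, but no measured pair contains a 2-(dimethylamino)pyridin-4-yl group, and the change swaps the whole aromatic ring, so the direction cannot be read from the measured compounds. Compound 3 is therefore expected to land between the two measured values, at an estimated 55% with a wide range from 25% to 85%. The expected step from compound 2 is thus a number 25 percentage points lower from compound 2 to compound 3 (beyond the scatter), with little confidence in its size.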

Compound 3, largest response reached (reported as efficacy), in percent of the reference or control that the assay uses: 80%
For compound 3 the middle estimate is 25 percentage points below the measured one; the measured number falls inside the stated range.
By their numbers in this assay, from the lowest: compound 1; then compounds 2 and 3 (each within the scatter of the next).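

In this assay the position tolerates the exchange of the whole aromatic ring: swapping 3-cyano-4-fluorophenyl for 2-(dimethylamino)pyridin-4-yl gives no change at the digits printed from compound 2 to compound 3 (within the scatter), so the two groups cannot be told apart here. Measured against the 4-cyanophenyl group, the new group gives a number 50 percentage points higher from compound 1 to compound 3 (beyond the scatter), which leaves compound 1 apart from both other compounds. Compound 3 carries no nitrile, so a nitrile is not needed to reach the level of compound 2, while the nitrile of compound 1 does not bring it there.

Nothing available explains why these two different groups match each other in this read-out. On these data alone, it also remains open whether the dimethylamino group itself counts, which a bare pyridin-4-yl group, or a primary amine or morpholine in its place on the pyridine, would test.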